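The source may report more compounds than this note shows. Statements on the series, on what has been measured and on what is new or still open speak of the compounds shown alone.

Measured set in this assay:
compound 1 `Cc1ccc(-c2cc(CC(=O)c3c(O)cc(O)cc3O)n[nH]2)cc1`: in an assay for inhibition of protein arginine N-methyltransferase 1 (Rattus norvegicus), read by scintillation counting, with stated times of 15 min and 60 min, in the presence of a further agent that is not named here (on this read-out higher numbers stand for weaker inhibition and lower numbers for stronger inhibition), compound 1 gives 49000 nM.
compound 2 `CN(C)CCNC(=O)c1ccccc1Sc1cccc2ccccc12`: compound 2 gives > 200000 nM, which is a limit of the assay and not a number.
compound 3 `CN(C)CCNC(=O)c1ccccc1Sc1ccccc1`: compound 3 gives > 50000 nM, again a limit of the assay rather than a number.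

Compound 3 therefore stands at a limit, the one described by the limit of > 50000 nM in this assay, at which 1 of the 3 values shown sits; its position relative to compound 1 is only that it lies no lower than this limit, and the other limit, (the limit of > 200000 nM in this assay, at which 1 of the 3 values shown sits), belongs to compound 2 alone. Within the data shown here, no measured step between two compounds differing in one place exists in this set.

Compound 4 `CN(C)CCNC(=O)c1ccccc1Sc1ccccc1Cl` differs from compound 3 by chloro in place of hydrogen on an aromatic carbon of a six-membered aromatic ring of carbon only, ortho to a large group; read one bond further out, phenyl to 2-chlorophenyl. With compound 3 known only as a limit, no step size can be anchored; the expectation in this assay is a step of no more than the usual scatter, in either direction, with the reported result most likely again a limit.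

The estimate for compound 4 is 70000 nM, expected between 30000 nM and 200000 nM. The expected step is a step that the limit leaves unreadable from compound 3 to compound 4.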

Compound 4, half-maximal inhibitory concentration: > 50000 nM
Compound 4: only a limit was reported; the forecaster's own chance of this, stated with the estimate: 60%; the middle value is on the limit's open side.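

In this assay compound 4 gives > 50000 nM, a limit of the assay and not a number. Compound 3 gives > 50000 nM, also a limit. Among these compounds, no step between compound 3 and compound 4 can be read. As far as these compounds go, whether 2-chlorophenyl in place of phenyl alters inhibition at all in this assay stays open.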